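The source may hold more compounds than are shown below. What is called first, only, known or untested is meant among the compounds shown, and "the series" means these compounds.

Measured so far:
- Compound 1 `COc1ccc(Oc2ccccc2NC(C)=C2C(=O)CC(c3ccccc3)CC2=O)cc1OC`: 160 nM
- Compound 2 `CC(Nc1ccccc1Oc1ccc(C(C)O)cc1)=C1C(=O)CC(c2ccccc2)CC1=O`: 120 nM

In a functional assay on CCRF-CEM cells (Homo sapiens) for antiproliferative activity, read by cell counting, with a stated time of 96 h (on this read-out lower numbers stand for stronger inhibition and higher numbers for weaker inhibition), compound 2 gives 120 nM and stands level, within the scatter, with compound 1 at 160 nM. For the measured compounds named here, these two numbers are all that is known for the series so far.

The next compound is compound 3 `CCOc1ccccc1NC(C)=C1C(=O)CC(c2ccccc2)CC1=O`, which has ethyl in place of 4-(1-hydroxyethyl)phenyl on an oxygen on an aromatic ring.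

Going by the values given here, only one measured step bears on this change. In this assay, a 1.3-fold lower number from compound 1 to compound 2 (0.12 log units; within the scatter), and that step exchanges 4-(1-hydroxyethyl)phenyl for 3,4-dimethoxyphenyl at the same place. It therefore compares two groups that both keep the aromatic ring, and it stays within the scatter. Among the compounds with values here, no measured compound shows what happens when that ring is lost, so the step offers only weak guidance and the expectation remains wide. A moderately higher number is expected, though a result level with compound 2 would not be surprising. The expected change is a 2.9-fold higher number from compound 2 to compound 3 (0.46 log units; beyond the scatter). For compound 3 the estimate is 350 nM, with an expected range from 100 nM to 1500 nM.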

Compound 3, half-maximal inhibitory concentration: 190 nM
Compound 3: the middle estimate sits 1.8-fold (0.27 log units) above what was measured, and the stated range covers the measured number.
By their numbers in this assay, from the lowest: compounds 2, 1 and 3 (each within the scatter of the next).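

In this assay the aromatic ring on the oxygen proves dispensable at this position, something the earlier pair could not show, since both of its compounds kept that ring: ethyl in place of 4-(1-hydroxyethyl)phenyl gives (a 1.6-fold higher number from compound 2 to compound 3 (0.20 log units; within the scatter)) and ethyl in place of 3,4-dimethoxyphenyl gives (a 1.2-fold higher number from compound 1 to compound 3 (0.07 log units; within the scatter)), and both steps stay within the scatter. The substituent falls from 9 heavy atoms to 2, and the hydrogen-bond donor and acceptor of 4-(1-hydroxyethyl)phenyl go with it, yet compounds 1, 2 and 3 all stand level, so across these three compounds the size of the group on this oxygen does not separate the numbers. No measurement shown here explains why the position tolerates so large an exchange.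

What the compounds leave open is whether any group on this oxygen moves the number beyond the scatter, for instance a longer chain such as n-butyl, or a chain ending in an amine or a carboxylic acid. Going by these compounds, it is equally open whether a free hydroxyl in place of the ethoxy, with no carbon on the oxygen at all, would stay level with compound 3.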